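This account rests on a few compounds, and the source may have more. Where it says the series, first, only, none or still open, it means among the compounds named here.

Measured so far:
Compound 1, `Cc1ccccc1C(=O)Nc1ccc2nc(NC(=O)C3CCCCC3)sc2c1`, gives 0.085 ug/mL.
Compound 2, `CCCOC(=O)Nc1nc2ccc(NC(=O)c3c(Cl)cccc3Cl)cc2s1`, gives 0.0025 ug/mL.

Of the two numbers in a functional assay on WI-38 VA13 cells (Homo sapiens) for cytotoxicity (a higher number here means that more compound is needed for the effect, a lower number that less compound is needed), compound 2 stands at the lowest, and its distance from compound 1 lies beyond the usual scatter. Compound 3, `COc1ccc(Nc2nc3ccc(NC(=O)c4c(Cl)cccc4Cl)cc3s2)cc1`, is the one not yet measured. It differs from compound 2 in one place: 4-methoxyphenyl in place of propoxycarbonyl on a nitrogen on an aromatic ring. Among the compounds with values here, no pair of measured compounds shows this change, so nothing here tells how large its effect is. A moderate rise in the number is expected, a 3.2-fold higher number from compound 2 to compound 3 (0.51 log units; beyond the scatter). For compound 3 the estimated value in this assay is 0.008 ug/mL, in a range from 0.0015 ug/mL to 0.04 ug/mL.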

Compound 3, half-maximal effective concentration: 0.87 ug/mL
The estimate for compound 3 lay 110-fold (2.04 log units) below the measured number; measured number outside the range, above it.
By their numbers in this assay, from the lowest: compound 2; then compound 1; then compound 3.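

On a nitrogen on an aromatic ring, 4-methoxyphenyl in place of propoxycarbonyl gives in this assay a large change, a 350-fold higher number from compound 2 to compound 3 (2.54 log units; beyond the scatter). Within the data shown here, this is the first reading of how much this position matters: the group on that nitrogen alone can move the number far beyond the scatter. No available evidence bears on the reason for this step.

The compounds shown leave open whether the rise follows from losing the carbonyl and propyl chain or from gaining the aromatic ring. An acetyl group or an unsubstituted phenyl on the same nitrogen could separate these two readings.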